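Swapping a Carbamoyl for a Methylsulfanyl Group

The compounds below may be only part of what the source reports. "The series", "measured", "known", "first", "only" and "open" are said of these compounds alone.

In a functional assay on the whole organism (Tail, strain ICR) with Mus musculus as the target, in the tail flick test, with a stated time of 120 min, at a dose of 25 umol/kg by the oral route (on this read-out higher numbers stand for a stronger effect at the one dose given and lower numbers for a weaker effect), compound 3 `NC(=O)C[C@H](NC(=O)CN(c1ncnc2c1ncn2C1CCCCO1)C1CC1)C(=O)OCc1ccccc1` gives 29.2%, the highest of the three numbers shown. Compound 1 `CC[C@H](C)[C@H](NC(=O)CN(c1nc(Cl)nc2[nH]cnc12)C1CC1)C(=O)O` gives 21.4%, a number within the usual scatter of compound 3, so no order can be read between these two. Compound 2 `O=C(OCc1ccccc1)[C@@H]1CCCN1C(=O)CN(c1ncnc2c1ncn2C1CCCCO1)C1CC1` gives 17.5%, which lies beyond the scatter under compound 3. Compound 4 `CSCC[C@H](NC(=O)CN(c1ncnc2c1ncn2C1CCCCO1)C1CC1)C(=O)OCc1ccccc1` has not yet been measured in this assay. It differs from compound 3 in one place: (methylsulfanyl)methyl in place of carbamoyl on a saturated chain carbon, two bonds along the chain from an amide-type nitrogen and a carbonyl carbon. Going by the values given here, no measured pair shows a change of this kind, so its step size is unknown from the data, and a step no larger than the scatter is expected in either direction. Compound 4 is expected to give 25%, estimated to fall between 10% and 40%. The step of a number 4.2 percentage points lower from compound 3 to compound 4 (within the scatter) that this estimate implies is expected to stay within the scatter.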

Compound 4, a percentage reported as activity, at one dose (the size of the read-out at that dose, not a potency): 28.7%
Beside the measured number, compound 4's estimate is 3.7 percentage points below it; measured number inside the range.
By their numbers in this assay, from the lowest: compounds 2, 1, 4 and 3 (each within the scatter of the next, the first and the last beyond it).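

In this assay the step from the carbamoyl to the (methylsulfanyl)methyl group, a number a number 0.5 percentage points lower from compound 3 to compound 4 (within the scatter), leaves the two compounds indistinguishable, so this position on the saturated chain carbon accepts both groups at this one dose. The carbamoyl has a hydrogen-bond donor and the (methylsulfanyl)methyl group has none, so that donor is not required for this read-out. Nothing measured here gives a reason for this result.

Still open, as far as these compounds go, is whether an amine or a carboxylic acid at this position would give a similar number. A longer chain bearing the same sulfur group also remains untested in the compounds shown.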